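The source may hold more compounds than are shown below. What is called first, only, known or untested is meant among the compounds shown, and "the series" means these compounds.

Compound 1 `CC(C)CSc1nc(N)nc2c1ncn2/C=C1/CC1(CO)CO` is the reference point of this set. In an ADME assay on Akata cells (Homo sapiens) for cytotoxicity, with a stated time of 7 days (a higher number here means that more compound is tolerated, a lower number that less compound is tolerated), compound 1 gives > 20000 nM, which is a limit of the assay rather than a measured number. Compound 2 `CCCCCOc1nc(N)nc2c1ncn2/C=C1/CC1(CO)CO` carries pentyloxy in place of isobutylsulfanyl on an aromatic carbon. In this assay compound 2 also stops at a limit, > 20000 nM. Compound 3 `Nc1nc(OCC(F)(F)F)c2ncn(/C=C3/CC3(CO)CO)c2n1` carries 2,2,2-trifluoroethoxy in place of isobutylsulfanyl on an aromatic carbon. In this assay compound 3 likewise reaches only a limit, > 20000 nM. The three steps among these compounds, a step that the two limits leave unreadable from compound 1 to compound 2, a step that the two limits leave unreadable from compound 1 to compound 3 and a step that the two limits leave unreadable from compound 2 to compound 3, cannot be read in size or direction because every value shown sits at the limit of > 20000 nM in this assay, at which 3 of the 3 values shown sit.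

Compound 4 `Nc1nc(OCc2ccccc2)c2ncn(/C=C3/CC3(CO)CO)c2n1` differs from compound 1 by benzyloxy in place of isobutylsulfanyl on an aromatic carbon. Going by the values given here, none of the measured steps offers a readable size, so they give no direction for this change; what they do show is that three different groups at this aromatic carbon all left the compound tolerated up to the limit. The step expected in this assay is a step that the limit leaves unreadable from compound 1 to compound 4, that is, no change beyond the scatter. Compound 4 is accordingly estimated at 25000 nM, within a range from 10000 nM to 60000 nM, and a report of a limit rather than a number is the most likely outcome.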

Compound 4, half-maximal cytotoxic concentration: > 20000 nM
Compound 4: no number, only a limit; the forecaster's own chance of this, stated with the estimate: 80%; the middle value is on the limit's open side.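

In this assay compound 4 gives > 20000 nM, which is a limit of the assay and not a number. The steps linking compound 4 with compound 1, compound 2 and compound 3 cannot be read in size or direction, because no value shown gives a number: the limit of > 20000 nM in this assay, at which 4 of the 4 values shown sit. The compounds shown leave open what concentration each actually tolerates, and whether the four groups on this aromatic carbon differ at all.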